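Moving the Methyl Branch Along a Tetrazole Chain

This account rests on a few compounds, and the source may have more. Where it says the series, first, only, none or still open, it means among the compounds named here.

Three measured compounds share a core and differ in the side chain that ends in a tetrazole or carboxy group. In an assay on membranes from lung (Cavia porcellus) for binding affinity to cysteinyl leukotriene receptor (Homo sapiens) (a lower number here means a stronger inhibitor, a higher number a weaker inhibitor), compound 1 `CC(CCc1ccc(OCc2ccc3ccccc3n2)cc1)Cc1nnn[nH]1` gives 25 nM, the lowest of the three numbers and, since both gaps to the others lie beyond the scatter, the strongest binder among them. Compound 2 `c1ccc2nc(COc3ccc(OCCCc4nnn[nH]4)cc3)ccc2c1` gives 69 nM in this assay, and compound 3 `O=C(O)CCCOc1ccc(OCc2ccc3ccccc3n2)cc1` gives 1200 nM. Within the data shown here, the only single-point step among the measured compounds, a 17-fold higher number from compound 2 to compound 3 (1.24 log units; beyond the scatter), concerns the end group itself and not the shape of the chain. Compound 4 `CC(CCc1nnn[nH]1)Cc1ccc(OCc2ccc3ccccc3n2)cc1` keeps every atom of compound 1 but joins them differently: 3-(1H-tetrazol-5-yl)-1-methylpropyl in place of 2-((1H-tetrazol-5-yl)methyl)propyl on a saturated chain carbon bound to an aromatic carbon. Among the measured compounds shown here, no measured step bears directly on this change, since compound 2 differs from compound 1 in more than one place and the step from compound 2 to compound 3 swaps the end group. With the tetrazole kept and only the methyl branch relocated, a step within the scatter is expected, a 1.4-fold higher number from compound 1 to compound 4 (0.15 log units; within the scatter). Compound 4 is therefore estimated at 35 nM, with a range from 12 nM to 110 nM.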

Compound 4, inhibition constant: 12 nM
Compound 4: the middle estimate sits 2.9-fold (0.46 log units) above what was measured; the range from low to high includes it.
By their numbers in this assay, from the lowest: compound 4; then compound 1; then compound 2; then compound 3.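

With every atom kept and only the joining changed, moving from 2-((1H-tetrazol-5-yl)methyl)propyl to 3-(1H-tetrazol-5-yl)-1-methylpropyl gives in this assay a measurable gain: a 2.1-fold lower number from compound 1 to compound 4 (0.32 log units; beyond the scatter) is a modest step, but it lies beyond the scatter. Among these compounds, the earlier compounds showed only that the end group matters, whereas this pair shows that the way the chain is assembled also changes the number, even with the same tetrazole and the same counts of atoms, donors and acceptors. Nothing shown here explains why the two arrangements differ.

On these data alone, whether the gain depends on the methyl branch itself remains open, and an ethyl branch or a chain with no branch on this arrangement would test that. A longer chain between the tetrazole and the branched carbon is equally untested by these compounds.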